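Aryl versus heteroaryl on the ring amide nitrogen

A few compounds are considered here, and "the series" means these few. Any claim that something is new, unique, unknown or untested is made for them only; others in the source may bear on it.

Compound 1 `CCOC(=O)c1sc(N2C(=O)CSC2c2cccc(C(=O)NCCCCn3cccn3)c2)nc1C` is the weaker of the two compounds that give a number in a functional assay on HOS-TE85 cells (Homo sapiens) for inhibition, read by CCK-8 assay, with a stated time of 72 h; a lower number here means a stronger inhibitor, a higher number a weaker inhibitor: compound 1 gives 430 nM. Compound 2 `C#Cc1cccc(N2C(=O)CSC2c2cccc(C(=O)NCCCCc3ccccc3)c2)c1` gives 149 nM in this assay. Compound 3 `O=C(NCCCCc1ccccc1)c1cccc(C2SCC(=O)N2c2cnccn2)c1` reaches only > 1000 nM in this assay, which is a limit of the assay and not a number. For the measured compounds named here, the one measured step at the ring amide nitrogen is an at least 6.7-fold higher number from compound 2 to compound 3 (0.82 log units; beyond the scatter), and compound 3 sits at the limit of > 1000 nM in this assay, at which 1 of the 3 values shown sits, so the loss there is at least that large.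

Compound 4 `O=C(NCCCCn1cccn1)c1cccc(C2SCC(=O)N2c2cccc(C3CC3)c2)c1` differs from compound 1 by 3-cyclopropylphenyl in place of 5-(ethoxycarbonyl)-4-methyl-1,3-thiazol-2-yl on an amide-type nitrogen in a ring. The measured step runs the other way: pyrazin-2-yl entering for 3-ethynylphenyl cost at least a modest loss, whereas here a five-membered aromatic ring with 2 hetero atoms leaves and a six-membered aromatic ring of carbon only enters. The butyl amide side of compound 4 matches compound 1, not compound 2, so the comparison is indirect and the measured step is taken only as a guide to direction. A gain is expected, and the estimated step is a 2.4-fold lower number from compound 1 to compound 4 (0.38 log units; beyond the scatter). Compound 4 is expected at 180 nM, with a range of 70 nM to 500 nM.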

Compound 4, half-maximal inhibitory concentration: 299 nM
Compound 4: middle estimate off by 1.7-fold (0.22 log units), on the low side; low and high end bracket the measured number.
By their numbers in this assay, from the lowest: compounds 2, 4 and 1 (each within the scatter of the next, the first and the last beyond it). At a limit, above all of these: compound 3.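

The step of a 1.4-fold lower number from compound 1 to compound 4 (0.16 log units; within the scatter) lies within the scatter, so in this assay the two groups cannot be told apart on this amide-type nitrogen in a ring when the pyrazolylbutyl amide is held constant. This is new: 5-(ethoxycarbonyl)-4-methyl-1,3-thiazol-2-yl and 3-cyclopropylphenyl share this place without a readable change, although the entering group has no hydrogen-bond acceptors and the leaving group has 4. For the compounds shown here, a hetero-aromatic ring here therefore carries no loss in this pair, and compound 3 goes against any wider reading: compound 3 gives > 1000 nM, which is a limit of the assay and not a number. Nothing shown gives a cause for the step from the thiazole to the cyclopropylphenyl group.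

Still open, on these data alone, is whether pyrazin-2-yl would fall as far on the pyrazolylbutyl amide as it does on the phenylbutyl amide, since that step is known on the phenylbutyl side only. Also open, as far as these compounds go, is what the ester adds to the thiazole, which a carboxylic acid or a plain hydrogen in place of the ethoxycarbonyl would address, and whether an unsubstituted phenyl keeps the activity of the substituted aryl groups.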